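This account rests on a few compounds, and the source may have more. Where it says the series, first, only, none or still open, it means among the compounds named here.

Three compounds have been measured in an assay on cells for inhibition of Voltage-dependent T-type calcium channel subunit alpha-1I (Homo sapiens), read by patch clamp; on this read-out lower numbers stand for stronger inhibition and higher numbers for weaker inhibition:

Compound 1 `CN(C)CCCCCSC1=Nc2ccccc2C(CC(=O)NCc2ccc(F)cc2)N1c1ccc(-c2ccccc2)cc1` gives 6100 nM.
Compound 2 `CN(C)CCCCCSC1=Nc2ccccc2C(CC(=O)NCc2ccccc2)N1c1ccccc1` gives 3200 nM.
Compound 3 `CN(C)CCCCCSC1=Nc2ccccc2C(CC(=O)NCc2ccccc2)N1c1ccc(-c2ccccc2)cc1` gives 1760 nM.

Compound 3 carries the lowest number of the three. The step of a 3.5-fold lower number from compound 1 to compound 3 (0.54 log units; beyond the scatter) lies beyond the usual scatter, so compound 3 is clearly stronger than compound 1. The step of a 1.8-fold lower number from compound 2 to compound 3 (0.26 log units; within the scatter) stays within the scatter, so compound 3 and compound 2 cannot be told apart on these numbers.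

Compound 4 `O=C(CC1c2ccccc2N=C(SCCCCCN2CCCC2)N1c1ccc(-c2ccccc2)cc1)NCc1ccccc1` is the next compound to be measured. It differs from compound 3 in one place: pyrrolidin-1-yl in place of dimethylamino on a saturated chain carbon, five bonds along the chain from a sulfur. Neither of the two measured steps bears on this change, since both of them alter a group on an aromatic carbon and leave the chain amine untouched. There is therefore nothing in the data to suggest a shift in either direction, and the expected step is one within the scatter, a 1.0-fold lower number from compound 3 to compound 4 (0.02 log units; within the scatter). For compound 4 the estimated value in this assay is 1700 nM, with a likely range from 700 nM to 4500 nM.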

Compound 4, half-maximal inhibitory concentration: 810 nM
Compound 4: the middle estimate sits 2.1-fold (0.32 log units) above what was measured; the range from low to high includes it.
By their numbers in this assay, from the lowest: compound 4; then compounds 3, 2 and 1 (each within the scatter of the next, the first and the last beyond it).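

In this assay, the amine at the end of the chain also affects the read-out: pyrrolidin-1-yl in place of dimethylamino gives a 2.2-fold lower number from compound 3 to compound 4 (0.34 log units; beyond the scatter). Among these compounds, the earlier steps changed only groups on aromatic carbons, so this is the first sign that a change on a saturated chain carbon, five bonds along the chain from a sulfur, can move the number, though the step is modest and rests on one pair of compounds. No supporting data explain the shift.

Still open, from the compounds shown here alone, is how other amines at this place would behave, such as piperidin-1-yl, morpholin-4-yl or diethylamino. It is also unknown whether the same swap would give a similar step on a shorter or longer chain, or on the core of compound 2.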